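From Bromo to Ethyl: A Small Step on a Shared Core

The source may hold more compounds than are shown below. What is called first, only, known or untested is meant among the compounds shown, and "the series" means these compounds.

Compound 2 `Cc1nc2ccccc2c(=O)n1NC(=O)Nc1ccc(Br)cc1` and compound 1 `Cc1nc2ccccc2c(=O)n1NC(=O)Nc1ccc(Cl)cc1` share one core and differ only in the halogen on the outer carbon ring. In a functional assay on the whole organism with Mus musculus as the target, with a stated time of 0.5 h (a lower number here means that less compound is needed, a higher number that more compound is needed for the effect), compound 1 needs 300 mg/kg, and compound 2 needs 300 mg/kg; the step of no change at the digits printed from compound 1 to compound 2 (within the scatter), so compound 2 stands level with compound 1. Compound 3 `CCc1ccc(NC(=O)Nn2c(C)nc3ccccc3c2=O)cc1` keeps everything except this one spot, where (ethyl in place of bromo on an aromatic carbon). Within the data shown here, no measured pair swaps a halogen for a carbon chain, so the only step that bears on this change is the halogen swap from compound 1 to compound 2, which was flat. Taking that step as the sole guide, the expectation is that the move to ethyl also leaves this assay roughly where it was, with the step of no change at the digits printed from compound 2 to compound 3 (within the scatter) expected to stay within the scatter. Compound 3 is therefore estimated at 300 mg/kg, with a range from 100 mg/kg to 1000 mg/kg.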

Compound 3, minimum effective dose: 300 mg/kg
Compound 3: middle estimate and measured number agree at the digits printed; the measured number falls inside the stated range.
By their numbers in this assay, from the lowest: compounds 1, 2 and 3 (each within the scatter of the next).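

In this assay, the swap of bromo for ethyl gives no change at the digits printed from compound 2 to compound 3 (within the scatter) and the swap of chloro for ethyl gives no change at the digits printed from compound 1 to compound 3 (within the scatter) in the same read-out. The earlier compounds shown here showed only one halogen exchanged for another, whereas this result shows that a small carbon chain can stand at this spot, on an aromatic carbon para to a large group, with the dose level with both halogens. No measurement offered here explains why the dose stays level across these three groups.

On these data alone, whether an amine, a carboxylic acid or a longer chain such as butyl would keep the dose level at this spot remains open. So does whether any group here can bring the dose down, since all three compounds stand level and changes elsewhere on the shared core do not appear among them.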